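Cyclohexyl in place of cyclopropyl on the amine nitrogen

The source may hold more compounds than are shown below. What is called first, only, known or untested is meant among the compounds shown, and "the series" means these compounds.

Compound 1 `COc1ccc(NC2=CC(=O)c3c(nc4n3[C@H]3OC[C@@H](O)[C@H]3OC4)C2=O)cc1`: 2150 nM
Compound 2 `O=C1C(N2CCC2)=CC(=O)c2c1nc1n2[C@H]2OC[C@@H](O)[C@H]2OC1`: > 16000 nM (a limit)
Compound 3 `O=C1C(NC2CC2)=CC(=O)c2c1nc1n2[C@H]2OC[C@@H](O)[C@H]2OC1`: > 4000 nM (a limit)

In a functional assay on MGC-803 cells (Homo sapiens) for inhibition, read by sulforhodamine B assay (a lower number here means a stronger inhibitor, a higher number a weaker inhibitor), compound 3 has only a limit, > 4000 nM and no actual number. Compound 4 `O=C1C(NC2CCCCC2)=CC(=O)c2c1nc1n2[C@H]2OC[C@@H](O)[C@H]2OC1` carries cyclohexyl in place of cyclopropyl on an amine nitrogen and is otherwise the same. Among the compounds with values here, two measured steps bear on this change: an at least 1.8-fold higher number from compound 1 to compound 3 (0.26 log units; that floor lies within the scatter) gives only a floor that lies within the scatter, and an at least 7.4-fold higher number from compound 1 to compound 2 (0.87 log units; beyond the scatter) lies beyond it. Neither step brings in cyclohexyl, so only a modest change of uncertain direction is expected, and the estimated step is a step that the limit leaves unreadable from compound 3 to compound 4 in this assay for now. Expected for compound 4 is 6000 nM with a range from 2000 nM to 18000 nM as the estimate.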

Compound 4, half-maximal inhibitory concentration: > 8000 nM
Compound 4 ended at the assay's limit (the forecaster's own chance of this, stated with the estimate: 35%); middle value at least 1.3-fold (0.12 log units) away from the limit.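

In this assay, within the data shown here, cyclohexyl in place of 4-methoxyphenyl on the amine nitrogen gives an at least 3.7-fold higher number from compound 1 to compound 4 (0.57 log units; beyond the scatter), a floor that, unlike the one for cyclopropyl in compound 3, lies beyond the scatter. Compound 4 has only a limit, > 8000 nM. The steps among compound 2, compound 3 and compound 4 cannot be read.

As far as these compounds go, whether cyclohexyl and cyclopropyl differ at all therefore stays open. So does whether the lower number of compound 1 depends on its methoxy group, which a plain phenyl on the same nitrogen would test.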